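Replacing the basic side chain with a small amine

The source may hold more compounds than are shown below. What is called first, only, known or untested is meant among the compounds shown, and "the series" means these compounds.

In a physicochemical assay for lipophilicity (on this read-out lower numbers stand for lower lipophilicity and higher numbers for higher lipophilicity), compound 3 `CC(C)c1cc(CN(C)C)cc(C(C)C)c1O` gives 2.5, the lowest of the three numbers measured. Compound 1 `CC(C)c1cc(Cl)cc(C(C)C)c1O` gives 5.34 and compound 2 `CC(C)c1cc(I)cc(C(C)C)c1O` gives 5.75, so compound 3 sits far below both, a number 2.84 log units lower from compound 1 to compound 3 (beyond the scatter) and a number 3.25 log units lower from compound 2 to compound 3 (beyond the scatter), while the halogen exchange itself moves less, a number 0.41 log units higher from compound 1 to compound 2 (beyond the scatter).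

Compound 4 `CC(C)c1cc(N)cc(C(C)C)c1O` differs from compound 3 in one place: amino in place of (dimethylamino)methyl on an aromatic carbon.

Within the data shown here, no measured step involves an amino group, so the steps in hand only frame the question. They show that putting (dimethylamino)methyl in place of a halogen pulled this assay down by a large amount, which leaves compound 3 already at a low level. The amino group that enters brings a donor and an acceptor on a single heavy atom, whereas the group that leaves carried four heavy atoms and one acceptor. The author therefore expects compound 4 to remain near the level of compound 3, with the step from compound 3 to compound 4 expected to be about a number 0.20 log units higher from compound 3 to compound 4 (within the scatter), well within the scatter. For compound 4 the estimate is 2.7, with a range from 2 to 3.4.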

Compound 4, partition coefficient: 3.1
Estimate against measurement, compound 4: 0.40 log units below, within the range that was stated.
By their numbers in this assay, from the lowest: compound 3; then compound 4; then compound 1; then compound 2.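

In this assay, among these compounds, the amino group at this place, on an aromatic carbon para to a hydroxy group, gives the first comparison of (dimethylamino)methyl with another nitrogen-bearing group, and the step of a number 0.60 log units higher from compound 3 to compound 4 (beyond the scatter) shows that the two are not interchangeable here, though this gap is small beside those to the halogens. Set against the halogens, amino stays far down, with a number 2.24 log units lower from compound 1 to compound 4 (beyond the scatter) and a number 2.65 log units lower from compound 2 to compound 4 (beyond the scatter), so among these compounds a low number at this position does not depend on the 4 heavy atoms of (dimethylamino)methyl: amino, with 1 heavy atom, also reaches it, and both nitrogen-bearing groups lie under both halogens with no compound here going against that order. Nothing available explains why compound 4 ends above compound 3.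

The compounds shown leave open whether a methylamino or an acetamido group at this same place would stay with the nitrogen-bearing groups or move toward the halogens. They also leave open where a group without nitrogen, such as a carboxylic acid or a hydroxymethyl group, would fall on this scale.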